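The compounds below may be only part of what the source reports. "The series", "measured", "known", "first", "only" and "open" are said of these compounds alone.

Measured so far, each compound with its result:

compound 1, `Nc1nccc(-c2cnc3ccccc3c2)n1`, 31.9%
compound 2, `Nc1nccc(-c2ccnc3ccccc23)n1`, 77.4%
compound 3, `Cc1nc2ccccn2c1-c1ccnc(Nc2ccc(C=O)s2)n1`, 49.5%

All three were tested in a functional assay on PC-3 cells (Homo sapiens) for cytotoxicity, read by sulforhodamine B assay, with a stated time of 48 h, tested at 50 uM; a lower number here means less inhibition, a higher number more inhibition at the concentration tested (going by the name of the read-out). Among the three numbers, compound 2 stands highest. Its nearest neighbour is compound 3, whose result lies lower by a margin beyond the usual scatter, and compound 1 lies lowest, further still from compound 2 and also beyond the scatter. Within the data shown here, no pair among the measured compounds differs in only one place, so no single structural step has been measured directly.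

Compound 4, `Cc1ccc(Nc2nccc(-c3ccnc4ccccc34)n2)cc1`, is the next compound to be examined in this assay. It is built from compound 2 by one change: 4-methylphenyl in place of hydrogen on a nitrogen on an aromatic ring. Put one bond further out, the amino group becomes a (4-methylphenyl)amino group. Compound 3 carries a related substitution on its amino nitrogen and gives a lower number than compound 2, but its core also differs, so this is only a hint. The step from compound 2 to compound 4 in this assay is therefore expected to be modest, more likely downward than upward, and possibly within the scatter: a number 12.4 percentage points lower from compound 2 to compound 4 (beyond the scatter). Compound 4 is estimated at 65%, within a range from 35% to 90%.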

Compound 4, a percentage reported as inhibition, at one concentration (the size of the read-out at that concentration, not a potency): 100%
Compound 4: the middle estimate sits 35 percentage points below what was measured; the measured number lies above the stated range.
By their numbers in this assay, from the lowest: compound 1; then compound 3; then compound 2; then compound 4.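

In this assay, among these compounds, the amino nitrogen of compound 2 accepts a large substituent without a loss of inhibition, and this is the first single change measured directly: 4-methylphenyl in place of hydrogen gives a number 22.6 percentage points higher from compound 2 to compound 4 (beyond the scatter). The earlier compounds shown here offered only a loose hint from a different core, whereas this step, on an unchanged core, points upward. No measured evidence here explains the rise, so no cause can be assigned to it.

The compounds shown do not tell whether the methyl group plays any part, or how a plain phenyl, a morpholine or a carboxylic acid on that ring would compare. Compound 4 reaches 100% at a single concentration, which leaves its potency open.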